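This account rests on a few compounds, and the source may have more. Where it says the series, first, only, none or still open, it means among the compounds named here.

Of the compounds shown here, three have so far been measured in an ADME assay on microsomes from liver (Rattus norvegicus) for metabolic stability, read by LC-MS; a lower number here means slower removal, a higher number faster removal of the compound. Compound 2 `COc1cc(N2CCN(C(=O)N[C@@H](C)c3cccc4ccccc34)CC2)ccc1-n1cnc(C)n1` gives 110 mL.min-1.g-1, the highest of the three numbers. Compound 1 `COc1cc(N2CCN(C(=O)Cn3ncc4ccccc43)CC2)ccc1-c1cnc(C)o1` gives 77 mL.min-1.g-1, and the gap between compound 1 and compound 2 lies within the scatter, so the two numbers cannot be placed in any order. Compound 3 `COc1cc(N2CCN(C(=O)Cn3cnc4c(C(F)(F)F)cccc43)CC2)ccc1-c1cnc(C)o1` gives 12 mL.min-1.g-1, and its gap to compound 2 lies well beyond the scatter.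

Compound 4 `COc1cc(N2CCN(C(=O)N[C@@H](C)c3cccc4ccccc34)CC2)ccc1-n1cnc(C)c1` has not yet been measured. It differs from compound 2 in one place only: 4-methyl-1H-imidazol-1-yl in place of 3-methyl-1H-1,2,4-triazol-1-yl on an aromatic carbon. Among the compounds with values here, compounds 1 and 3 carry a different ring at this place and differ from compound 2 elsewhere as well, so they show only their own two values and give no measured pair for the change in hand. Within the data shown here, no measured pair differs in just this way. The size of the step must therefore be guessed. The expected step from compound 2 to compound 4 in this assay is small, a 1.1-fold higher number from compound 2 to compound 4 (0.04 log units; within the scatter), and none beyond the scatter. For compound 4 in this assay the estimate is 120 mL.min-1.g-1, with a range from 55 mL.min-1.g-1 to 260 mL.min-1.g-1.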

Compound 4, intrinsic clearance in microsomes: 150 mL.min-1.g-1
For compound 4 the middle estimate is 1.3-fold (0.10 log units) below the measured one, and the stated range covers the measured number.
By their numbers in this assay, from the lowest: compound 3; then compounds 1, 2 and 4 (each within the scatter of the next).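

Within the data shown here, compound 2 and compound 4 form the first measured pair that isolates this position, on an aromatic carbon ortho to a methoxy group and para to a large group. In this assay, replacing 3-methyl-1H-1,2,4-triazol-1-yl with 4-methyl-1H-imidazol-1-yl gives a 1.4-fold higher number from compound 2 to compound 4 (0.13 log units; within the scatter). The ring size and heavy-atom count stay the same, while the ring goes from 3 nitrogen atoms to 2 and from 3 hydrogen-bond acceptors to 2, and this exchange does not separate the two compounds in this read-out; nothing available explains that outcome.

This single pair cannot show whether the same exchange would also leave the number unresolved with a different group at the other end of the molecule, such as the side chains of compound 1 and compound 3. It also leaves open how the number would respond to a more different group at this position, such as a carboxylic acid or an open-chain amine.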